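Swapping One Aminated Base on a Saturated Core

A few compounds are considered here, and "the series" means these few. Any claim that something is new, unique, unknown or untested is made for them only; others in the source may bear on it.

In an ADME assay on WI-38 cells (Homo sapiens) for inhibition, read by MTT assay, with a stated time of 72 h (on this read-out higher numbers stand for weaker inhibition and lower numbers for stronger inhibition), compound 1 `Nc1ncn(CCC2(N)OC(=O)C(OCc3ccccc3)=C2OCc2ccccc2)c(=O)n1` gives only a limit, > 100000 nM, and the limit of > 100000 nM in this assay, at which 1 of the 3 values shown sits, records that it sits at that limit rather than at a measured number. The two other compounds carry an unsaturated exocyclic linkage instead of the saturated, amine-bearing core of compound 1: compound 2 `O=C1O/C(=C\Cn2ncc(=O)[nH]c2=O)C(OCc2ccccc2)=C1OCc1ccccc1` gives 24600 nM in this assay, and compound 3 `O=C1O/C(=C\Cn2ccc(NC(=O)c3ccccc3)nc2=O)C(OCc2ccccc2)=C1OCc1ccccc1` gives 8490 nM in this assay. Compound 4 `Nc1ccn(CCC2(N)OC(=O)C(OCc3ccccc3)=C2OCc2ccccc2)c(=O)n1` keeps the saturated core of compound 1 and differs from it by a group of 8 heavy atoms (4 carbon, 3 nitrogen, 1 oxygen; one six-membered aromatic ring with 2 hetero atoms) in place of a group of 8 heavy atoms (3 carbon, 4 nitrogen, 1 oxygen; one six-membered aromatic ring with 3 hetero atoms), on a saturated chain carbon, two bonds along the chain from a saturated ring carbon, a group of 8 heavy atoms (4 carbon, 3 nitrogen, 1 oxygen; one six-membered aromatic ring with 2 hetero atoms) in place of a group of 8 heavy atoms (3 carbon, 4 nitrogen, 1 oxygen; one six-membered aromatic ring with 3 hetero atoms), on a saturated chain carbon, two bonds along the chain from a saturated ring carbon. For the measured compounds named here, no measured pair differs in one place, so no step size is known from the data. The expected step is an at least 1.1-fold lower number from compound 1 to compound 4 (0.04 log units; that floor lies within the scatter), nothing beyond the usual scatter. Compound 4 is therefore estimated at 90000 nM, within 20000 nM to 400000 nM, with a real chance that this assay again returns only a limit.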

Compound 4, half-maximal inhibitory concentration: 88900 nM
Estimate against measurement, compound 4: 1.0-fold (0.01 log units) above; the measured number falls inside the stated range.
By their numbers in this assay, from the lowest: compound 3; then compound 2; then compound 4. At a limit, above all of these: compound 1.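

In this assay compound 4 gives 88900 nM on the saturated core, so this position now carries a measured number where compound 1 offered none. Placing the group with one six-membered aromatic ring with 2 hetero atoms where the ring with 3 hetero atoms stood reads as an at least 1.1-fold lower number from compound 1 to compound 4 (0.05 log units; that floor lies within the scatter) and so establishes no shift beyond the usual scatter, though a larger one is not excluded. The step stays a floor because compound 1 is held at a limit: the limit of > 100000 nM in this assay, at which 1 of the 4 values shown sits.

From the compounds shown here alone, how far compound 1 truly lies from compound 4 remains unknown, and no single change links this saturated core to the unsaturated linkage of compound 2 and compound 3. The compounds shown also leave open what a carboxylic acid or a longer chain at this place would give.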